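The source may hold more compounds than are shown below. What is called first, only, known or untested is meant among the compounds shown, and "the series" means these compounds.

Values in a functional assay on A549 cells (Homo sapiens) for inhibition, read by sulforhodamine B assay, with a stated time of 72 h; a higher number here means a weaker inhibitor, a lower number a stronger inhibitor:
- compound 1 `Nc1sc(-c2ccc(Cl)cc2)c(-c2ccc(Cl)cc2)c1C(=O)N1CCCCC1`: 4620 nM
- compound 2 `Nc1sc(-c2ccc(Cl)cc2)c(-c2ccc(Cl)cc2)c1C(=O)Nc1ccccc1`: 25000 nM
- compound 3 `CCCCNC(=O)c1c(N)sc(-c2ccc(Cl)cc2)c1-c1ccc(Cl)cc1`: 8170 nM

Compound 3 stands at 8170 nM. The measured step on the piperidin-1-yl side, a 1.8-fold higher number from compound 1 to compound 3 (0.25 log units; within the scatter), leaves those two compounds unseparated. The step on the anilino side, a 3.1-fold lower number from compound 2 to compound 3 (0.49 log units; beyond the scatter), is modest but clear.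

Next in the series is compound 4 `CN1CCN(C(=O)c2c(N)sc(-c3ccc(Cl)cc3)c2-c2ccc(Cl)cc2)CC1`, with 4-methylpiperazin-1-yl in place of butylamino on a carbonyl carbon.

The most relevant measurement is a 1.8-fold higher number from compound 1 to compound 3 (0.25 log units; within the scatter), since compound 1 also carries a six-membered non-aromatic ring at this carbonyl carbon. That step stayed within the scatter, so the swap between butylamino and a ring of this kind has so far made no clear difference. The larger 5.4-fold higher number from compound 1 to compound 2 (0.73 log units; beyond the scatter) bears less directly, as no aromatic group enters here. Within the data shown here, no measured compound carries 4-methylpiperazin-1-yl, so the effect of this group is untested and the range stays wide.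

The expected change is a 1.5-fold lower number from compound 3 to compound 4 (0.17 log units; within the scatter), which would not go beyond the scatter. For compound 4 the estimated value in this assay is 5500 nM, with an expected range of 2200 nM to 15000 nM.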

Compound 4, half-maximal inhibitory concentration: 590 nM
Compound 4: middle estimate off by 9.3-fold (0.97 log units), on the high side; measured number outside the range, below it.
By their numbers in this assay, from the lowest: compound 4; then compounds 1 and 3 (each within the scatter of the next); then compound 2.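

In this assay, a six-membered non-aromatic ring on the carbonyl carbon does not by itself set the level: compound 1 and compound 4 both carry such a ring, yet the change of ring gives a 7.8-fold lower number from compound 1 to compound 4 (0.89 log units; beyond the scatter), a step beyond the scatter. The position is also more responsive than the earlier amides showed, since butylamino and piperidin-1-yl could not be separated, whereas the new group gives a 14-fold lower number from compound 3 to compound 4 (1.14 log units; beyond the scatter) and a 42-fold lower number from compound 2 to compound 4 (1.63 log units; beyond the scatter), both large, and compound 4 now lies clearly below all three others. Nothing measured here explains this gain.

Open, on these data alone, is how an unsubstituted piperazin-1-yl or a morpholin-4-yl on the same carbonyl carbon would compare with compound 4, which would show whether the second ring nitrogen or its methyl goes with the step. Also open, as far as these compounds go, is whether the step holds with fluoro or methoxy in place of the chlorines, as all four compounds share the same core.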